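The compounds below may be only part of what the source reports. "The series", "measured", "known", "first", "only" and "open" are said of these compounds alone.

Measured compounds in a functional assay on SK-BR-3 cells (Homo sapiens) for inhibition, read by CellTiter-Glo, with a stated time of 72 h; a lower number here means a stronger inhibitor, a higher number a weaker inhibitor:
- compound 1 `CC(C)c1nn(-c2ccc(C(N)=O)c(N[C@H]3CC[C@H](O)CC3)c2)c2nccc(-n3cnc(-c4ccncc4)c3)c12`: 165 nM
- compound 2 `COc1cncc(-c2ccnc3c2c(C(C)C)nn3-c2ccc(C(N)=O)c(N[C@H]3CC[C@H](O)CC3)c2)c1`: 451 nM
- compound 3 `CC(C)c1nn(-c2ccc(C(N)=O)c(N[C@H]3CC[C@H](O)CC3)c2)c2nccc(-n3cnc(-c4cncnc4)c3)c12`: 387 nM

Compound 3 holds the second highest of the three numbers in this assay. Its nearest neighbour is compound 2, with which it lies within the scatter (a 1.2-fold lower number from compound 2 to compound 3 (0.07 log units; within the scatter)); compound 1 stands apart from it, giving a lower number (a 2.3-fold higher number from compound 1 to compound 3 (0.37 log units; beyond the scatter)).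

Compound 4 `CC(C)c1nn(-c2ccc(C(N)=O)c(N[C@H]3CC[C@H](O)CC3)c2)c2nccc(-c3ccoc3)c12` is not yet measured. It differs from compound 3 by furan-3-yl in place of 4-(pyrimidin-5-yl)-1H-imidazol-1-yl on an aromatic carbon. Going by the values given here, no measured pair carries this exact exchange. The closest guide is the step from compound 1 to compound 2, where the two-ring group was replaced by a single six-membered ring and the number rose modestly (a 2.7-fold higher number from compound 1 to compound 2 (0.44 log units; beyond the scatter)); the step from compound 2 to compound 3 shows that the larger two-ring group and the single ring sit within the scatter of one another. A single five-membered ring in compound 4 is therefore expected to give a number near compound 3 or somewhat higher, so the step from compound 3 to compound 4 is estimated as a 1.7-fold higher number from compound 3 to compound 4 (0.23 log units; within the scatter). Compound 4 is accordingly estimated at 650 nM, with a range from 200 nM to 2200 nM.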

Compound 4, half-maximal inhibitory concentration: > 10000 nM
Compound 4 gave a limit, no number (the forecaster's own chance of this, stated with the estimate: 5%); at least 15-fold (1.18 log units) between middle value and limit.
By their numbers in this assay, from the lowest: compound 1; then compounds 3 and 2 (each within the scatter of the next). At a limit, above all of these: compound 4.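

In this assay compound 4 gives a limit and not a number: the limit of > 10000 nM in this assay, at which 1 of the 4 values shown sits. The place opposite the ring nitrogen had so far shown only modest changes, but furan-3-yl is far less well accepted there than any earlier group: an at least 25-fold higher number from compound 3 to compound 4 (1.41 log units; beyond the scatter), an at least 22-fold higher number from compound 2 to compound 4 (1.34 log units; beyond the scatter) and an at least 60-fold higher number from compound 1 to compound 4 (1.78 log units; beyond the scatter). Compound 2 also carries a single aromatic ring at this place and gives 451 nM, so the lack of a second ring does not by itself go with loss of a measurable number.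

The compounds shown do not separate the effect of the furan oxygen from that of the five-membered ring or of the smaller group. Thiophen-3-yl, phenyl or 1H-pyrazol-4-yl at this place would bear on that, and the true size of these steps remains unknown.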